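Isomeric aryl swap on the sulfonamide nitrogen

The source may hold more compounds than are shown below. What is called first, only, known or untested is meant among the compounds shown, and "the series" means these compounds.

Going by the values given here, in a functional assay on cells (leukaemia cell line, Homo sapiens) for inhibition, read by sulforhodamine B assay, with a stated time of 48 h (a higher number here means a weaker inhibitor of growth, a lower number a stronger inhibitor of growth), compound 2 `Cc1cc(Cl)ccc1NS(=O)(=O)c1ccc(-c2cnc(C3CC3)o2)cc1` gives 277 nM and stands lowest of the two numbers so far, while compound 1 `O=S(=O)(Nc1cc(F)cc(F)c1)c1ccc(-c2cnc(C3CC3)o2)cc1` gives 2140 nM on the same core. Compound 3 `Cc1ccc(Cl)c(NS(=O)(=O)c2ccc(-c3cnc(C4CC4)o3)cc2)c1` has the same atoms as compound 2, joined differently, with 2-chloro-5-methylphenyl in place of 4-chloro-2-methylphenyl on a sulfonamide nitrogen. Among the compounds with values here, only one measured step bears on this: a 7.7-fold lower number from compound 1 to compound 2 (0.89 log units; beyond the scatter) at that same place, a modest change beyond the scatter. Within the data shown here, it shows that the group there can move the number, but the data hold no pair of isomers to fix size or direction. Among the measured compounds shown here, a moderate rise is expected, no larger than that step, and it is estimated as a 1.6-fold higher number from compound 2 to compound 3 (0.21 log units; within the scatter) in this assay with a real chance of none beyond the scatter. The estimated value for compound 3 is 450 nM with 130 nM to 1500 nM as the expected range.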

Compound 3, concentration for 50% growth inhibition: 48.8 nM
Compound 3: middle estimate off by 9.2-fold (0.96 log units), on the high side, and the stated range ends above it.
By their numbers in this assay, from the lowest: compound 3; then compound 2; then compound 1.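

Changing 4-chloro-2-methylphenyl to 2-chloro-5-methylphenyl on a sulfonamide nitrogen gives a 5.7-fold lower number from compound 2 to compound 3 (0.75 log units; beyond the scatter) in this assay, so with the atoms unchanged, their arrangement on this aryl group alone moves the number beyond the scatter. The earlier step from compound 1 to compound 2 changed the atoms as well and could not separate the two. Replacing 3,5-difluorophenyl with 2-chloro-5-methylphenyl gives a 44-fold lower number from compound 1 to compound 3 (1.64 log units; beyond the scatter), the widest span yet seen at this place, and nothing measured here explains the gap between the two isomers.

Which of the chlorine and the methyl carries the result remains open, as does whether either could be replaced by a methoxy group or a nitrile. The compounds shown also do not tell whether this isomer order holds on any other core.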